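The source may report more compounds than this note shows. Statements on the series, on what has been measured and on what is new or still open speak of the compounds shown alone.

In an ADME assay on Vero cells (Chlorocebus sabaeus) for cytotoxicity, read by resazurin assay, with a stated time of 2 days (on this read-out lower numbers stand for higher toxicity in this test and higher numbers for lower toxicity in this test), compound 2 `CC(=O)OC[C@H]1O[C@@H](CC(=O)/C=C/c2cccc(NC(=O)Nc3ccccc3)c2)[C@H](OC(C)=O)[C@@H](OC(C)=O)[C@@H]1OC(C)=O` gives 180000 nM, the second highest of the three numbers shown. Compound 3 `CC(=O)OC[C@H]1O[C@@H](CC(=O)/C=C/c2cccc(NC(=O)Nc3ccccc3)c2)[C@@H](OC(C)=O)[C@@H](OC(C)=O)[C@@H]1OC(C)=O` sits nearest, giving 102000 nM; the step of a 1.8-fold lower number from compound 2 to compound 3 (0.25 log units; within the scatter) rests on (the fact that compounds 2 and 3 differ only in the configuration as drawn). Within the data shown here, compound 1 `O=C(/C=C/c1ccc(NC(=O)Nc2ccc3ccccc3c2)cc1)C[C@@H]1O[C@H](CO)[C@@H](O)[C@H](O)[C@H]1O` gives 1020000 nM, the only value separated from compound 2 by more than the scatter. Compound 4 `COc1ccc(NC(=O)Nc2cccc(/C=C/C(=O)C[C@@H]3O[C@H](COC(C)=O)[C@@H](OC(C)=O)[C@H](OC(C)=O)[C@H]3OC(C)=O)c2)c([N+](=O)[O-])c1` differs from compound 2 by 4-methoxy-2-nitrophenyl in place of phenyl on an amide-type nitrogen. Among the measured compounds shown here, none of the measured steps bears on this change: the single measured step concerns configuration alone, stayed within the scatter, and says nothing about putting 4-methoxy-2-nitrophenyl in place of phenyl. The expected step is therefore no change at the digits printed from compound 2 to compound 4 (within the scatter), nothing beyond the scatter. The estimate for compound 4 is 180000 nM, between 60000 nM and 540000 nM.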

Compound 4, half-maximal cytotoxic concentration: 730000 nM
For compound 4 the middle estimate is 4.1-fold (0.61 log units) below the measured one; measured number above the stated range.
By their numbers in this assay, from the lowest: compounds 3 and 2 (each within the scatter of the next); then compounds 4 and 1 (each within the scatter of the next).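

On the amide-type nitrogen, 4-methoxy-2-nitrophenyl in place of phenyl gives a 4.1-fold higher number from compound 2 to compound 4 (0.61 log units; beyond the scatter) in this assay and so points towards lower toxicity in this test. The earlier step between compounds differing in one place stayed within the scatter, so this is the first such change shown to move the number beyond it. Nothing measured here explains this step.

From the compounds shown here alone, whether 4-methoxyphenyl alone or 2-nitrophenyl alone would give the same step stays open. So does the result of a 2-aminophenyl group in the same place.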